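Cyclohexyl for a nitrile chain, at the limit

This account rests on a few compounds, and the source may have more. Where it says the series, first, only, none or still open, it means among the compounds named here.

Measured in a toxicity assay on HT-29 cells (Homo sapiens) for cytotoxicity; on this read-out lower numbers stand for higher toxicity in this test and higher numbers for lower toxicity in this test:
- compound 1 `CC(C)CCn1nc(C(=O)N[C@H]2COc3ccccc3N(C)C2=S)nc1Cc1ccccc1`: > 100000 nM
- compound 2 `CN1C(=S)[C@@H](NC(=O)c2nc(Cc3ccccc3)n(CCCO)n2)COc2ccccc21`: > 100000 nM
- compound 3 `CN1C(=S)[C@@H](NC(=O)c2nc(Cc3ccccc3)n(CCCCC#N)n2)COc2ccccc21`: > 100000 nM

Compound 3 gives > 100000 nM, which is a limit and not a number. It shares this position with the other measured compounds: the limit of > 100000 nM in this assay, at which 3 of the 3 values shown sit.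

Compound 4 `CN1C(=S)[C@@H](NC(=O)c2nc(Cc3ccccc3)n(C3CCCCC3)n2)COc2ccccc21` keeps the shared core and the benzyl group, but has cyclohexyl in place of 4-cyanobutyl on an aromatic nitrogen.

Within the data shown here, three measured steps bear on this change, as all of them alter the chain on that nitrogen. They are a step that the two limits leave unreadable from compound 1 to compound 2, a step that the two limits leave unreadable from compound 1 to compound 3 and a step that the two limits leave unreadable from compound 2 to compound 3. Going by these compounds, their sizes cannot be read, and none of the three compounds carries a ring at this place, so cyclohexyl is untested there.

The expectation rests on compound 3, whose > 100000 nM is a limit. No measured change in this chain has yet produced a readable number, so no step beyond the usual scatter is expected in this assay, and no direction can be given. The expected change is a number no higher from compound 3 to compound 4 (the limit leaves the size open). Compound 4 is estimated at 100000 nM, with an expected range from 60000 nM to 150000 nM, and it will most likely be reported only as a limit again.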

Compound 4, half-maximal cytotoxic concentration: > 100000 nM
Compound 4: only a limit was reported (the forecaster's own chance of this, stated with the estimate: 85%); the middle value sits exactly at the limit.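

In this assay compound 4 gives > 100000 nM, which is a limit and not a number. Its steps from compound 1, compound 2 and compound 3 therefore cannot be read. What stays open is whether any group on this aromatic nitrogen changes the read-out at all, as all four compounds share one position: the limit of > 100000 nM in this assay, at which 4 of the 4 values shown sit.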